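A Methyl Gives Way to 1,1-Difluoroethyl on Compound 2

The source may hold more compounds than are shown below. What is called first, only, known or untested is meant among the compounds shown, and "the series" means these compounds.

Solubility is a basic property of any candidate compound, since a compound must dissolve before it can be tested reliably. Two related amides have been measured so far. In a physicochemical assay for solubility, read by turbidimetry, measured as kinetic solubility, at pH 6.8 (a higher number here means a more soluble compound, a lower number a less soluble compound), compound 1 (`C#Cc1cc(C(=O)NCCCCc2ccccc2)cc(C2SCC(=O)N2c2ccccc2OC)c1`) gives 10000 nM. Compound 2 (`Cc1cccc(N2C(=O)CSC2c2cccc(C(=O)NCCCCc3ccccc3)c2)c1`) gives 10000 nM, which places it level with compound 1 on the numbers available.

The next structure, compound 3 (`CC(F)(F)c1cccc(N2C(=O)CSC2c2cccc(C(=O)NCCCCc3ccccc3)c2)c1`), keeps the rest of compound 2 and makes a single change: 1,1-difluoroethyl in place of methyl on an aromatic carbon. The new group sits on a six-membered aromatic ring of carbon only, meta to a large group.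

Within the data shown here, no measured pair shows this change on its own, so there is no direct precedent for it. Among the measured compounds shown here, the only guide is that compound 1 and compound 2 share a value in this assay although their structures differ. No shift beyond the usual scatter is therefore expected, and the expected change is a 1.3-fold lower number from compound 2 to compound 3 (0.10 log units; within the scatter). For compound 3 the estimated value is 8000 nM, with an expected range from 3000 nM to 16000 nM.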

Compound 3, solubility: 10000 nM
Beside the measured number, compound 3's estimate is 1.3-fold (0.10 log units) below it; low and high end bracket the measured number.
By their numbers in this assay, from the lowest: compounds 1, 2 and 3 (each within the scatter of the next).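

Replacing methyl with 1,1-difluoroethyl gives, in this assay, no change at the digits printed from compound 2 to compound 3 (within the scatter). This is the only pair shown that differs in one place, so this position, on an aromatic carbon of a six-membered aromatic ring of carbon only and meta to a large group, now has a direct reading: a group of 4 heavy atoms, including 2 fluorine, stands in for a group of 1 heavy atom with no shift in the solubility read-out beyond the usual scatter. Nothing else given here speaks to the reason for this result.

The compounds shown carry only carbon and fluorine substituents at this place, so the result says nothing about how a group of another kind, such as an amine or a carboxylic acid, would read there. It also leaves open whether 1,1-difluoroethyl would read the same on another carbon of this ring, or whether a longer chain at this position would keep the number level.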